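Chain Length at the Anilide End of a Diaryl Urea

The source may hold more compounds than are shown below. What is called first, only, known or untested is meant among the compounds shown, and "the series" means these compounds.

Compound 1: `CCc1ccc(NC(=O)Nc2c(C(C)C)cccc2C(C)C)cc1` — 100 nM
Compound 2: `CCCCc1ccc(NC(=O)Nc2c(C(C)C)cccc2C(C)C)cc1` — 29 nM
Compound 3: `CCCCCCCc1ccc(NC(=O)Nc2c(C(C)C)cccc2C(C)C)cc1` — 19 nM

The three measured compounds share one core and differ only in the length of the chain on the anilide ring. In an assay on isolated protein for inhibition of acyl-CoA:cholesterol acyltransferase (Oryctolagus cuniculus) (a higher number here means a weaker inhibitor, a lower number a stronger inhibitor), compound 1 gives 100 nM. Compound 2 stands second highest of the three numbers: its nearest neighbour is compound 3, whose number lies within the scatter of it, while compound 1 sits furthest away, beyond the scatter.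

The steps among the measured compounds point one way. Lengthening the chain gives a 3.4-fold lower number from compound 1 to compound 2 (0.54 log units; beyond the scatter) and a 5.3-fold lower number from compound 1 to compound 3 (0.72 log units; beyond the scatter), both modest, but the further extension gives only a 1.5-fold lower number from compound 2 to compound 3 (0.18 log units; within the scatter), which lies within the scatter. Compound 4, `CCCCCCCCCCCCCc1ccc(NC(=O)Nc2c(C(C)C)cccc2C(C)C)cc1`, is not yet measured; it differs from compound 2 by nonyl in place of hydrogen on a saturated chain carbon, four bonds along the chain from an aromatic carbon.

The step from compound 2 to compound 3 bears most directly on this change, and it was within the scatter. A further gain in this assay beyond the scatter is therefore not expected; the number for compound 4 is expected to sit close to that of compound 3, with the step of a 1.8-fold lower number from compound 2 to compound 4 (0.26 log units; within the scatter) estimated. For compound 4 the estimate in this assay is 16 nM, expected between 6 nM and 45 nM.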

Compound 4, half-maximal inhibitory concentration: 11 nM
Estimate against measurement, compound 4: 1.5-fold (0.16 log units) above, and the stated range covers the measured number.
By their numbers in this assay, from the lowest: compounds 4, 3 and 2 (each within the scatter of the next, the first and the last beyond it); then compound 1.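

Among the compounds shown here, with compound 4, the chain at this position turns out to carry a gain that the earlier steps had not settled: in this assay the change gives a 2.6-fold lower number from compound 2 to compound 4 (0.42 log units; beyond the scatter), whereas the shorter extension to compound 3 stayed within the scatter, and the whole span of lengthening amounts to a 9.1-fold lower number from compound 1 to compound 4 (0.96 log units; beyond the scatter). The last extension itself, a 1.7-fold lower number from compound 3 to compound 4 (0.24 log units; within the scatter), does not separate its two compounds, so the gain from compound 2 emerges only across two steps that cannot each be told from the scatter, and the added nonyl brings no rise in the number beyond the scatter at this place on the chain. Nothing shown here gives a reason for this behaviour of the chain.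

From the compounds shown here alone, whether a longer chain than that of compound 4 would bring the number down further or send it back up stays open, since the final step cannot be read as a change. Also open, going by these compounds, is how a branched chain, or a chain ending in a carboxylic acid or an amine, would behave at this place in this assay.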